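Swapping a Side Chain in a Small Series

The compounds below may be only part of what the source reports. "The series", "measured", "known", "first", "only" and "open" are said of these compounds alone.

Compound 1, `NC(=O)CC[C@H](NC(=O)CN(c1ncnc2c1ncn2C1CCCCO1)C1CC1)C(=O)OCc1ccccc1`: 37.8%
Compound 2, `C[C@@H](O)[C@H](NC(=O)CN(c1nc(Cl)nc2[nH]cnc12)C1CC1)C(=O)OCc1ccccc1`: 29.9%
Compound 3, `O=C(CN(c1nc(Cl)nc2[nH]cnc12)C1CC1)N[C@@H](CO)C(=O)O`: 43.9%

These values come from a functional assay on the whole organism (Tail, strain ICR) with Mus musculus as the target, in the tail flick test, with a stated time of 90 min, at a dose of 25 umol/kg by the oral route; on this read-out lower numbers stand for a weaker effect and higher numbers for a stronger effect at the one dose given. On the numbers shown, compound 1 stands second highest of the three, with compound 3 nearest and compound 2 furthest; both gaps lie within the scatter, so the three compounds cannot be told apart. Compound 4, `CC[C@H](C)[C@H](NC(=O)CN(c1ncnc2c1ncn2C1CCCCO1)C1CC1)C(=O)OCc1ccccc1`, has not yet been measured. It differs from compound 1 in one place: sec-butyl in place of 2-carbamoylethyl on a saturated chain carbon bound to an amide-type nitrogen and a carbonyl carbon. Going by the values given here, no step between measured compounds is available for guidance, and the three measured numbers sit close together, so in this assay no step beyond the scatter is expected in either direction. For compound 4 the estimated value is 38%, between 22% and 54%, meaning an expected step of a number 0.2 percentage points higher from compound 1 to compound 4 (within the scatter).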

Compound 4, a percentage reported as activity, at one dose (the size of the read-out at that dose, not a potency): 22.6%
Beside the measured number, compound 4's estimate is 15.4 percentage points above it, and the stated range covers the measured number.
By their numbers in this assay, from the lowest: compounds 4, 2, 1 and 3 (each within the scatter of the next, the first and the last beyond it).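

Going by these compounds alone, replacing 2-carbamoylethyl with sec-butyl on this saturated chain carbon in this assay gives a number 15.2 percentage points lower from compound 1 to compound 4 (beyond the scatter) and is the only step so far that shows this side chain can change the read-out. The group that leaves has a hydrogen-bond donor and acceptor and the group that enters has neither, but a single swap cannot link that difference to the result. No measurement shown here explains the step. From the compounds shown here alone, whether a carboxylic acid or an amine at this place would give a value closer to that of compound 1 or compound 4 remains open.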